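Working notes: methoxy in place of dimethylamino

The source may report more compounds than this note shows. Statements on the series, on what has been measured and on what is new or still open speak of the compounds shown alone.

Measured so far in a functional assay on CCRF-CEM cells (Homo sapiens) for inhibition (on this read-out higher numbers stand for weaker inhibition of growth and lower numbers for stronger inhibition of growth), as follows
- compound 1 `CN(C)c1ccc(NS(=O)(=O)c2c(F)c(F)c(F)c(F)c2F)cc1` gives 320 nM
- compound 2 `Cc1ccc(NS(=O)(=O)c2c(F)c(F)c(F)c(F)c2F)cc1C` gives 68 nM
- compound 3 `O=S(=O)(Nc1ccc2c(c1)OCCO2)c1c(F)c(F)c(F)c(F)c1F` gives 51 nM

In this assay compound 1 has the highest number of the three, and so the weakest inhibition of growth. Compound 2 and compound 3 both lie lower, beyond the scatter, and within the scatter of each other.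

Compound 4 `COc1ccc(NS(=O)(=O)c2c(F)c(F)c(F)c(F)c2F)cc1` has not yet been measured. Its change from compound 1 is methoxy in place of dimethylamino on an aromatic carbon (methoxy in place of dimethylamino on an aromatic carbon, para to a large group). Among the compounds with values here, no two measured compounds differ in one place only, so no measured step speaks directly to this change. The expectation rests on the other two compounds: compound 3 (51 nM) also has oxygen on an aromatic carbon, and neither it nor compound 2 (68 nM) carries dimethylamino. Compound 4 is therefore expected to sit closer to these two than to compound 1. The expected change is a 5.3-fold lower number from compound 1 to compound 4 (0.73 log units; beyond the scatter) toward a lower number, beyond the scatter, meaning stronger inhibition of growth. Compound 4 is estimated at 60 nM (expected range 25 nM to 150 nM).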

Compound 4, concentration for 50% growth inhibition: < 10 nM
Compound 4: no number, only a limit (the forecaster's own chance of this, stated with the estimate: 2%); middle value at least 6.0-fold (0.77 log units) from the limit.
By their numbers in this assay, from the lowest: compounds 3 and 2 (each within the scatter of the next); then compound 1. At a limit, below all of these: compound 4.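

In this assay compound 4 gives < 10 nM, which is a limit of the assay and not a number. Methoxy in place of dimethylamino on this aromatic carbon, para to a large group, gives an at least 32-fold lower number from compound 1 to compound 4 (1.50 log units; beyond the scatter), the first one-place comparison in the series, and it shows that the read-out is sensitive to the group at this position, even though the two groups have the same hydrogen-bond donor and acceptor counts and neither carries a net charge. The step can be read only as a minimum, and its full size stays unknown because of where the value sits: the limit of < 10 nM in this assay, at which 1 of the 4 values shown sits.

Still open, from the compounds shown here alone, is how far the change depends on methoxy itself and how far on the loss of dimethylamino, a question that a hydroxyl, a primary amine or an ethoxy group at the same carbon would help to settle. Also open is whether the effect holds with a different sulfonyl half, as every compound shown carries the same pentafluorophenyl group.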